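Swapping the amide substituent on a benzimidazole urea

The source may report more compounds than this note shows. Statements on the series, on what has been measured and on what is new or still open speak of the compounds shown alone.

Of the compounds shown here, three have been measured in an assay on isolated protein for inhibition of Gonadotropin-releasing hormone receptor (Homo sapiens); on this read-out lower numbers stand for stronger inhibition and higher numbers for weaker inhibition. Compound 1, `COc1ccc([N+](=O)[O-])cc1CSc1nc2cc(NC(=O)NC(C)(C)C)ccc2n1Cc1ccccc1`, gives 28 nM. Compound 2, `COc1ccc([N+](=O)[O-])cc1CSc1nc2cc(NC(=O)NC(C)C)ccc2n1C(C)C`, gives 600 nM. Compound 3, `CCCn1c(SCc2cc([N+](=O)[O-])ccc2OC)nc2cc(NC(=O)NC(C)(C)C)cc(C(=O)N(C)C)c21`, gives 270 nM. Compound 3 therefore holds the second highest number of the three: its gap to compound 2 is beyond the scatter, and its gap to compound 1 is wider still, so compound 1 is clearly the strongest of the three measured compounds.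

Compound 4, `CCCn1c(SCc2cc([N+](=O)[O-])ccc2OC)nc2cc(NC(=O)NC(C)(C)C)cc(C(=O)NCc3ccncc3)c21`, has not yet been measured. It differs from compound 3 in one place: ((pyridin-4-yl)methyl)amino in place of dimethylamino on a carbonyl carbon. Within the data shown here, no measured pair in this set shows this kind of exchange, so there is no direct precedent for its effect. The change adds a hydrogen-bond donor and an aromatic ring at the carbonyl carbon while everything else stays the same. Compound 4 is expected to land near compound 3, with a step of a 1.4-fold lower number from compound 3 to compound 4 (0.13 log units; within the scatter) that is small and perhaps not beyond the scatter. The estimate for compound 4 is 200 nM, with a range from 60 nM to 700 nM.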

Compound 4, half-maximal inhibitory concentration: 61 nM
Beside the measured number, compound 4's estimate is 3.3-fold (0.52 log units) above it; measured number inside the range.
By their numbers in this assay, from the lowest: compound 1; then compound 4; then compound 3; then compound 2.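

In this assay, putting ((pyridin-4-yl)methyl)amino in place of dimethylamino on the carbonyl carbon gives a 4.4-fold lower number from compound 3 to compound 4 (0.65 log units; beyond the scatter) and so moves the number beyond the scatter. Among these compounds, this is the first pair in the set that differs in one place, and it shows that this position accepts a much larger group and that the choice of group there changes the reading. The exchange brings in a ring, a hydrogen-bond donor and a hydrogen-bond acceptor together, and no supporting measurement shows which of these matters or why the number falls. Benzylamino, which keeps the ring but has carbon in place of the ring nitrogen, would help to separate those features. From the compounds shown here alone, whether the ring nitrogen's location or the length of the link matters remains open, and (pyridin-3-yl)methylamino and (2-(pyridin-4-yl)ethyl)amino would address those questions.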